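The source may hold more compounds than are shown below. What is called first, only, known or untested is meant among the compounds shown, and "the series" means these compounds.

Three compounds share one core and differ only in the group on the amine nitrogen. Compound 1 `O=C1C=C(NCc2ccccc2)C(=O)c2c1nc1n2[C@H]2OC[C@@H](O)[C@H]2OC1` carries benzyl, and in a functional assay on MGC-803 cells (Homo sapiens) for inhibition, read by sulforhodamine B assay (a lower number here means a stronger inhibitor, a higher number a weaker inhibitor), compound 1 gives 2670 nM. Compound 2 `O=C1C=C(Nc2ccc(C(F)(F)F)cc2)C(=O)c2c1nc1n2[C@H]2OC[C@@H](O)[C@H]2OC1` carries 4-(trifluoromethyl)phenyl and gives 2820 nM, while compound 3 `CCCc1ccc(NC2=CC(=O)c3nc4n(c3C2=O)[C@H]2OC[C@@H](O)[C@H]2OC4)cc1` carries 4-propylphenyl and gives 1560 nM. Compound 3 shows the lowest number of the three, but the steps of a 1.7-fold lower number from compound 1 to compound 3 (0.23 log units; within the scatter) and a 1.8-fold lower number from compound 2 to compound 3 (0.26 log units; within the scatter) both lie within the scatter, so the three stand level. Compound 4 `O=C1C=C(Nc2ccc(Br)cc2)C(=O)c2c1nc1n2[C@H]2OC[C@@H](O)[C@H]2OC1` differs from compound 3 by bromo in place of propyl on an aromatic carbon. The step of a 1.8-fold lower number from compound 2 to compound 3 (0.26 log units; within the scatter) bears on this most directly, as it also exchanged the group on an aromatic carbon of that ring and moved little; the step of a 1.1-fold higher number from compound 1 to compound 2 (0.02 log units; within the scatter) was small too. A step of a 1.4-fold higher number from compound 3 to compound 4 (0.15 log units; within the scatter) is therefore expected, nothing beyond the scatter. Compound 4 is estimated at 2200 nM, within 1100 nM to 4500 nM.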

Compound 4, half-maximal inhibitory concentration: 1010 nM
Estimate against measurement, compound 4: 2.2-fold (0.34 log units) above, and the stated range ends above it.
By their numbers in this assay, from the lowest: compounds 4, 3, 1 and 2 (each within the scatter of the next, the first and the last beyond it).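

Bromo in place of propyl gives a 1.5-fold lower number from compound 3 to compound 4 (0.19 log units; within the scatter) and so shows that, at this spot on the aromatic ring, one bromine atom stands level with a three-carbon chain. Yet the same spot can matter: bromo in place of trifluoromethyl gives a 2.8-fold lower number from compound 2 to compound 4 (0.45 log units; beyond the scatter) and 4-bromophenyl in place of benzyl gives a 2.6-fold lower number from compound 1 to compound 4 (0.42 log units; beyond the scatter) as the first steps in this series beyond the scatter. Nothing available explains these differences. From the compounds shown here alone, how chloro, methoxy or an amine would fare at this spot remains open. So does whether a longer chain than propyl would hold the number level.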